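Swapping a benzimidazole for a cycloheptyl urea: expected cytotoxicity

The compounds below may be only part of what the source reports. "The series", "measured", "known", "first", "only" and "open" are said of these compounds alone.

Measured so far:
compound 1 `Cc1nc(NC(=O)NC2CCCCC2)c(C)c(C(OC(C)(C)C)C(=O)O)c1-c1ccc2c(c1)CCCO2` 17000 nM
compound 2 `Cc1ccc(-c2c(C)nc(NC(=O)NC3CCOCC3)c(C)c2C(OC(C)(C)C)C(=O)O)cc1C` 29000 nM
compound 3 `Cc1ccc(-c2c(C)nc(Nc3nc4ccccc4n3C)c(C)c2C(OC(C)(C)C)C(=O)O)cc1C` 14000 nM

In an ADME assay on MT4 cells (Homo sapiens) for cytotoxicity, read by MTT assay (a higher number here means that more compound is tolerated, a lower number that less compound is tolerated), compound 3 gives the lowest of the three numbers; compound 1 sits within the scatter of it, while compound 2 lies beyond the scatter above it. Compound 4 `Cc1ccc(-c2c(C)nc(NC(=O)NC3CCCCCC3)c(C)c2C(OC(C)(C)C)C(=O)O)cc1C` is not yet measured. The change is cycloheptylcarbamoyl in place of 1-methyl-1H-benzimidazol-2-yl on a nitrogen on an aromatic ring. Going by the values given here, one measured step bears on this: a 2.1-fold lower number from compound 2 to compound 3 (0.32 log units; beyond the scatter), where a urea was replaced by the benzimidazole. Compound 4 reverses that direction, taking a urea back in, so a modest rise is expected, tempered by compound 1, whose urea value 17000 nM is within the scatter of compound 3. Compound 4 is therefore expected to show a 1.6-fold higher number from compound 3 to compound 4 (0.20 log units; within the scatter), landing near 22000 nM in this assay, with a range from 12000 nM to 40000 nM.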

Compound 4, half-maximal cytotoxic concentration: 7700 nM
The estimate for compound 4 lay 2.9-fold (0.46 log units) above the measured number, and the stated range ends above it.
By their numbers in this assay, from the lowest: compounds 4, 3, 1 and 2 (each within the scatter of the next, the first and the last beyond it).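

In this assay, cycloheptylcarbamoyl and 1-methyl-1H-benzimidazol-2-yl on this nitrogen cannot be told apart (a 1.8-fold lower number from compound 3 to compound 4 (0.26 log units; within the scatter)), so the higher number of compound 2 does not come with the urea link alone. What separates the two ureas is the group at their far end, cycloheptyl in place of oxan-4-yl (a 3.8-fold lower number from compound 2 to compound 4 (0.58 log units; beyond the scatter)). Nothing measured here explains that gap.

Still open, as far as these compounds go, is where other groups on the urea would fall, such as piperidin-4-yl, which carries an amine, or an open hexyl chain. From the compounds shown here alone, whether the same gap between cycloheptyl and oxan-4-yl holds on a different core is also open.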